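Chloro on the acetamidophenyl urea: compound 3 outlook

This account rests on a few compounds, and the source may have more. Where it says the series, first, only, none or still open, it means among the compounds named here.

Measured so far:
compound 1 `C#Cc1cccc(NC(=O)Nc2cccc(-c3nc(-c4ccc(NC(=O)c5cccnc5)cc4Cl)no3)c2)c1` — > 10000 nM
compound 2 `CC(=O)Nc1ccc(NC(=O)Nc2cccc(-c3nc(-c4ccc(NC(=O)c5cccnc5)cc4Cl)no3)c2)cc1` — > 10000 nM

In a functional assay on MDA-MB-231 cells (Homo sapiens) for antiproliferative activity, read by MTT assay, with a stated time of 72 h (on this read-out higher numbers stand for weaker inhibition and lower numbers for stronger inhibition), compound 1 gives > 10000 nM, which is a limit of the assay and not a number. In this assay compound 2 gives > 10000 nM, again a limit rather than a number. The step that the two limits leave unreadable from compound 1 to compound 2 is therefore unreadable. Compound 2 thus stands at the limit of > 10000 nM in this assay, at which 2 of the 2 values shown sit, and has no number of its own to anchor a comparison.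

Compound 3 `CC(=O)Nc1ccc(NC(=O)Nc2cccc(-c3nc(-c4ccc(NC(=O)c5cccnc5)cc4Cl)no3)c2)cc1Cl` differs from compound 2 by chloro in place of hydrogen on an aromatic carbon. Within the data shown here, no measured step bears on this change, and the only step available is itself unreadable, so neither direction nor size can be drawn from the data. The expected step is a step that the limit leaves unreadable from compound 2 to compound 3, which is to say no change beyond the scatter is expected. Compound 3 is therefore expected near 15000 nM, with a range from 5000 nM to 50000 nM, most likely reported once more as a limit.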

Compound 3, half-maximal inhibitory concentration: > 10000 nM
Compound 3 ended at the assay's limit; the forecaster's own chance of this, stated with the estimate: 80%; the middle value does not contradict the limit.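

In this assay compound 3 gives > 10000 nM, a limit of the assay and not a number, so the steps to compound 3 from compound 1 and compound 2 cannot be read. The compounds shown leave open whether any group on the amide-type nitrogen gives a readable number.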